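The source may hold more compounds than are shown below. What is called first, only, known or untested is meant among the compounds shown, and "the series" means these compounds.

Working notes on the series. In a physicochemical assay for lipophilicity (on this read-out lower numbers stand for lower lipophilicity and higher numbers for higher lipophilicity), compound 3 `CCCNC(=O)c1cc(C(=O)NC)nn1[C@@H](C)c1ccccc1` gives 4.4, the highest of the three measured numbers. Compound 1 `CNC(=O)c1cc(C(=O)N[C@H]2[C@@H]3C[C@@H](O)C[C@@H]32)n([C@@H](C)c2ccccc2)n1` gives 3.2 and compound 2 `CNC(=O)c1cc(C(=O)NCCO)n([C@@H](C)c2ccccc2)n1` gives 2.4. Compound 4 `CNC(=O)c1cc(C(=O)N[C@H]2CC[C@H](OC)CC2)n([C@@H](C)c2ccccc2)n1` differs from compound 3 in one place: 4-methoxycyclohexyl in place of propyl on an amide-type nitrogen.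

Going by the values given here, the steps that bear on this change are a number 1.20 log units higher from compound 1 to compound 3 (beyond the scatter), where propyl entered in place of a larger oxygen-bearing ring group, and a number 2.00 log units higher from compound 2 to compound 3 (beyond the scatter). Here the reverse direction applies, a larger ring group with an ether oxygen entering in place of propyl, so a small downward step in this assay is expected for compound 4, of about a number 0.20 log units lower from compound 3 to compound 4 (within the scatter), within the scatter. Compound 4 is therefore estimated at 4.2, in the range 3.7 to 4.7.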

Compound 4, distribution coefficient: 4.2
Compound 4: middle estimate and measured number agree at the digits printed, and the stated range covers the measured number.
By their numbers in this assay, from the lowest: compound 2; then compound 1; then compounds 4 and 3 (each within the scatter of the next).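

On the amide-type nitrogen in this assay, 4-methoxycyclohexyl in place of propyl gives a number 0.20 log units lower from compound 3 to compound 4 (within the scatter), so this read-out does not separate the two groups despite the added ring and hydrogen-bond acceptor. In place of 2-hydroxyethyl, the same group gives a number 1.80 log units higher from compound 2 to compound 4 (beyond the scatter), and in place of the group in compound 1 it gives a number 1.00 log units higher from compound 1 to compound 4 (beyond the scatter), both beyond the scatter. An oxygen in this group therefore does not by itself fix the number, as compound 4 carries an ether oxygen. As far as these compounds go, how an amine or carboxylic acid on this group would read remains open. No measured evidence accounts for these steps.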